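Phenyl to Trifluoromethyl: Expecting a Modest Step

The source may report more compounds than this note shows. Statements on the series, on what has been measured and on what is new or still open speak of the compounds shown alone.

In a functional assay for antagonist activity at Alpha-1A adrenergic receptor (Oryctolagus cuniculus) (on this read-out lower numbers stand for tighter binding and higher numbers for weaker binding), compound 3 `CN(C)C(=O)c1cccnc1NCCCN1CCN(c2ccccc2-c2ccccc2)CC1` gives 1.26 nM. Compound 1 `COc1ccccc1N1CCN(CCCNc2ncccc2C(=O)NC(C)(C)C)CC1` gives 1.26 nM in this assay, so compound 3 stands level with compound 1 at the digits shown, and together they hold the lowest of the three numbers. Compound 2 `COc1ccccc1N1CCN(CCCNc2ccncc2C(=O)N(C)C)CC1` gives 12.6 nM, a gap that lies beyond the scatter.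

Compound 4 `CN(C)C(=O)c1cccnc1NCCCN1CCN(c2ccccc2C(F)(F)F)CC1` has not yet been tested in this assay. It differs from compound 3 by trifluoromethyl in place of phenyl on an aromatic carbon. Going by the values given here, no measured pair shows this change, so its size is open. A step of only a modest size is expected, a 2.0-fold higher number from compound 3 to compound 4 (0.30 log units; within the scatter), because compound 1 gives 1.26 nM with a different group at the same aromatic carbon. Compound 4 is thus expected to give about 2.5 nM, within 0.7 nM to 9 nM.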

Compound 4, dissociation constant: 12.6 nM
The estimate for compound 4 lay 5.0-fold (0.70 log units) below the measured number; the whole stated range lies below it.
By their numbers in this assay, from the lowest: compounds 1 and 3 (each within the scatter of the next); then compounds 2 and 4 (each within the scatter of the next).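

In this assay, going by these compounds alone, the exchange at this aromatic carbon, ortho to a large group, is not a neutral swap: trifluoromethyl in place of phenyl brings a 10-fold higher number from compound 3 to compound 4 (1.00 log units; beyond the scatter), the first single-place comparison at this position. The number therefore responds to the group held here, at least for this pair. Nothing measured here gives a reason for the step.

The compounds shown leave open how a methyl group, a chlorine atom or a nitrile would read at this carbon. They also leave open whether the same exchange gives a similar step on the core of compound 1.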